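The compounds below may be only part of what the source reports. "The series", "measured", "known", "first", "only" and "open" are said of these compounds alone.

Measured so far:
Compound 1 `O=c1ccc2cc(OCc3cc(-c4ccccc4)no3)ccc2o1` — 43300 nM
Compound 2 `O=c1ccc2cc(OCc3cc(-c4ccccc4[N+](=O)[O-])no3)ccc2o1` — "not determined" (no result reported)
Compound 3 `O=c1ccc2cc(OCc3cn(-c4ccccc4)nn3)ccc2o1` — 41600 nM

The account follows a single series of compounds that share the same coumarin-free description: a common core carrying an ether-linked five-membered heteroaromatic ring bearing a phenyl substituent. In a functional assay on HL-60 cells (Homo sapiens) for cytotoxicity, read by MTT assay, with a stated time of 48 h (a lower number here means a stronger inhibitor, a higher number a weaker inhibitor), compound 3 gives 41600 nM. Its nearest neighbour is compound 1, which in this assay gives 43300 nM; the two numbers lie within the usual scatter of each other, so nothing separates them. Going by the values given here, compound 2 carries no result in this assay, so only two numbers are available, and both sit at the weak end of what a cytotoxicity assay usually resolves.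

Compound 4 `COc1ccc(-n2cc(COc3ccc4oc(=O)ccc4c3)nn2)cc1` differs from compound 3 in one place: methoxy in place of hydrogen on an aromatic carbon. Among the compounds with values here, no pair of measured compounds shows this change, so its effect has to be judged from the structural change alone. Because compound 3 gives 41600 nM and compound 1 gives 43300 nM in this assay, two numbers that differ only within the scatter across a larger change of the heteroaromatic ring, a small substituent on the phenyl is expected to move the number by no more than the scatter, in no particular direction.

Compound 4 is therefore expected to give 38000 nM in this assay, within a range of 15000 nM to 95000 nM, a step from compound 3 to compound 4 of a 1.1-fold lower number from compound 3 to compound 4 (0.04 log units; within the scatter).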

Compound 4, half-maximal inhibitory concentration: 46400 nM
Estimate against measurement, compound 4: 1.2-fold (0.09 log units) below; the range from low to high includes it.
By their numbers in this assay, from the lowest: compounds 3, 1 and 4 (each within the scatter of the next).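

In this assay, going by these compounds alone, the change from phenyl to 4-methoxyphenyl gives a 1.1-fold higher number from compound 3 to compound 4 (0.05 log units; within the scatter), the first step that isolates a single change. It shows that methoxy in place of hydrogen on this aromatic carbon, para to a large group, leaves the number within the scatter, so this replacement on the phenyl ring of compound 3 has no readable effect in this cell assay. The earlier compounds could not show this, as none of those with numbers formed a pair differing in one place, and nothing available here bears on why the number holds at this position.

One substituent at one position says little about the ring as a whole: an amine, a carboxylic acid or a longer alkoxy chain at the same place could still move the number beyond the scatter. As far as these compounds go, it also remains open whether methoxy would behave the same way on the phenyl ring of compound 1, and whether any change to the shared core would shift the number more than this one did.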